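The compounds below may be only part of what the source reports. "The series", "measured", "known", "first", "only" and "open" are said of these compounds alone.

For the measured compounds named here, in a functional assay on COLO 205 cells (Homo sapiens) for inhibition, read by sulforhodamine B assay, with a stated time of 48 h, tested at 50 uM (on this read-out higher numbers stand for more inhibition of growth at the one concentration tested and lower numbers for less inhibition of growth), compound 1 `COc1cc(/C=C/C(=O)/C=C/c2ccccc2)ccc1OCc1cn(CCCCOc2cc(=O)oc3ccccc23)nn1` gives 31%, while compound 2 `COc1cc(/C=C/C(=O)/C=C/c2ccco2)ccc1OCc1cn(CCCCOc2cc(=O)oc3ccccc23)nn1` gives 43%, the higher of the two numbers so far. Compound 3 `COc1cc(/C=C/C(=O)/C=C/c2cc(OC)c(OC)c(OC)c2)ccc1OCc1cn(CCCCOc2cc(=O)oc3ccccc23)nn1` differs from compound 2 at one place: 3,4,5-trimethoxyphenyl in place of furan-2-yl on a double-bonded chain carbon bound to a double-bonded chain carbon. Here, 3,4,5-trimethoxyphenyl replaces furan-2-yl. Going by the values given here, the one measured step at that place is modest: a number 12 percentage points higher from compound 1 to compound 2 (beyond the scatter). Among the compounds with values here, it offers only a loose guide, since no measured compound carries the methoxy groups. The expected change is a small fall, a number 5 percentage points lower from compound 2 to compound 3 (within the scatter), not expected to pass the scatter. For compound 3 the estimated value is 38%, within an expected range of 24% to 56%.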

Compound 3, percent growth inhibition at one concentration: 60%
Estimate against measurement, compound 3: 22 percentage points below; the whole stated range lies below it.
By their numbers in this assay, from the lowest: compound 1; then compound 2; then compound 3.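

At this place, on a double-bonded chain carbon bound to a double-bonded chain carbon, the order in this assay now extends past furan-2-yl: 3,4,5-trimethoxyphenyl gives a number 17 percentage points higher from compound 2 to compound 3 (beyond the scatter) and, against the plain ring, a number 29 percentage points higher from compound 1 to compound 3 (beyond the scatter) as well. The six-membered aromatic ring alone therefore does not fix the read-out, since phenyl stands lowest and 3,4,5-trimethoxyphenyl highest, with furan-2-yl between them. No measured evidence accounts for this order. Which of the methoxy groups matter remains open, as does whether a phenyl carrying one methoxy group, or a dimethylamino group, would reach the same level.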